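Amino to Methyl on the Core of Compound 2

A few compounds are considered here, and "the series" means these few. Any claim that something is new, unique, unknown or untested is made for them only; others in the source may bear on it.

Compound 1 `Nc1ncc(-c2ccccc2)c(-c2ccncc2)n1` and compound 2 `CC(C)(C)c1nc(N)ncc1-c1ccccc1` share a core and were both tested in a functional assay on the whole organism for inhibition, with Rattus norvegicus as the target, with stated times of 1 h and 3.5 h, at a dose of 100 mg/kg by the oral route; a lower number here means less inhibition, a higher number more inhibition at the dose given (going by the name of the read-out). In this assay compound 1 gives 48%, and compound 2 gives 46%. Going by the values given here, the single measured step, a number 2 percentage points lower from compound 1 to compound 2 (within the scatter), lies within the scatter, so the two values cannot be told apart and compound 2 stands at the same level as compound 1.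

Compound 3 `Cc1ncc(-c2ccccc2)c(C(C)(C)C)n1` has not yet been measured. It differs from compound 2 in one place: methyl in place of amino on an aromatic carbon. Among the compounds with values here, no measured step concerns an exchange at this aromatic carbon; the step from compound 1 to compound 2 touched a different position and was itself within the scatter. The data thus give no direction for this change, and any expectation rests on compound 2 alone.

Compound 3 is expected to give about 40% in this assay, within a range from 10% to 65%. This estimate means a step of a number 6 percentage points lower from compound 2 to compound 3 (within the scatter), expected to stay within the scatter, because compound 2 gives 46% and nothing measured points another way.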

Compound 3, a percentage reported as inhibition, in the whole organism at one dose (the size of the read-out at that dose, not a potency): 22%
For compound 3 the middle estimate is 18 percentage points above the measured one; low and high end bracket the measured number.
By their numbers in this assay, from the lowest: compound 3; then compounds 2 and 1 (each within the scatter of the next).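

In this assay the read-out falls with methyl in place of amino on the aromatic carbon between two ring nitrogen atoms: the change gives a number 24 percentage points lower from compound 2 to compound 3 (beyond the scatter) and is the first step among these compounds to lie beyond the scatter. The earlier exchange of pyridin-4-yl for tert-butyl, at a different place on the shared core, gave a number 2 percentage points lower from compound 1 to compound 2 (within the scatter) and so showed no measurable response to the group there. Going by these compounds alone, this position is therefore the one place so far where a single exchange moves the number, and the amino group on this carbon goes with the higher inhibition at the dose given, although this rests on one pair of compounds at one dose and is not a measure of potency.

The compounds shown leave open how a methylamino group, a dimethylamino group or a methoxy group on this carbon would read, and whether the same exchange would also lower the number on compound 1, which carries pyridin-4-yl in place of tert-butyl. No measurement at hand speaks to what lies behind the drop.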